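Changing the amine nitrogen substituent of compound 1

This account rests on a few compounds, and the source may have more. Where it says the series, first, only, none or still open, it means among the compounds named here.

Measured so far in a functional assay on A549 cells (Homo sapiens) for cytotoxicity, read by sulforhodamine B assay; a higher number here means a weaker inhibitor, a lower number a stronger inhibitor:
- compound 1 `C=C1[C@@H](OC(C)=O)C[C@@H]2[C@](C)(COC=O)[C@H](OC(C)=O)CC[C@@]2(C)[C@@H]1C[C@@H](Nc1ccccc1F)C1=CCOC1=O` gives 23600 nM in this series
- compound 2 `C=C1[C@@H](OC(C)=O)C[C@@H]2[C@](C)(CO[Si](C)(C)C(C)(C)C)[C@H](OC(C)=O)CC[C@@]2(C)[C@@H]1C[C@@H](Nc1ccccc1F)C1=CCOC1=O` gives 3190 nM in this series
- compound 3 `C=C1[C@@H](OC(C)=O)C[C@@H]2[C@](C)(COC=O)[C@H](OC(C)=O)CC[C@@]2(C)[C@@H]1C[C@@H](Nc1ccc(OC)cc1)C1=CCOC1=O` has no value yet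

Within the data shown here, compound 1 stands at 23600 nM as the higher of the two numbers so far, and compound 2 is its only neighbour. Compound 3 differs from compound 1 in one place. The structural change is 4-methoxyphenyl in place of 2-fluorophenyl on an amine nitrogen and it amounts to 4-methoxyphenyl in place of 2-fluorophenyl on an amine nitrogen.

Among the measured compounds shown here, the only measured step is a 7.4-fold lower number from compound 1 to compound 2 (0.87 log units; beyond the scatter) and it lies at another place, on an oxygen on a saturated carbon. For the measured compounds named here, nothing measured so far varies the group on the amine nitrogen, so that step serves only as a rough gauge of size in this assay for this series. A smaller step is expected here, possibly none beyond the scatter, and the data support no direction. The expected step is a 1.2-fold lower number from compound 1 to compound 3 (0.09 log units; within the scatter) as a working estimate. For compound 3 the estimated value is 19000 nM with an expected range from 6500 nM to 50000 nM for the coming measurement.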

Compound 3, half-maximal inhibitory concentration: 28900 nM
Compound 3: the middle estimate sits 1.5-fold (0.18 log units) below what was measured; the range from low to high includes it.
By their numbers in this assay, from the lowest: compound 2; then compounds 1 and 3 (each within the scatter of the next).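

In this assay, the change on the amine nitrogen from 2-fluorophenyl to 4-methoxyphenyl gives a 1.2-fold higher number from compound 1 to compound 3 (0.09 log units; within the scatter), so these two aryl groups cannot be told apart at this position. Among these compounds, the entering group carries a hydrogen-bond acceptor that the leaving group lacks, yet this swap stays within the scatter, whereas a 7.4-fold lower number from compound 1 to compound 2 (0.87 log units; beyond the scatter), at the other place, on an oxygen on a saturated carbon, remains the only step beyond it. No measured data on these groups bear on why the number holds at this position.

As far as these compounds go, both groups on the nitrogen are substituted phenyl rings, so it stays open whether a different kind of group there, such as a cyclohexyl ring, a pyridine ring or a longer alkyl chain, would move the number beyond the scatter. From the compounds shown here alone, it also stays open whether 4-methoxyphenyl would give a similar result alongside the silyl group of compound 2, which would show whether the two places act independently.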